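A few compounds are considered here, and "the series" means these few. Any claim that something is new, unique, unknown or untested is made for them only; others in the source may bear on it.

Measured so far in a functional assay on Jurkat cells (Homo sapiens) for antiproliferative activity, read by MTT assay, with a stated time of 72 h; a lower number here means a stronger inhibitor, a higher number a weaker inhibitor:
- compound 1 `COc1cc(-c2ncnn2-c2cccc(F)c2)cc(OC)c1OC`: > 10000 nM
- compound 2 `COc1cccc(-c2ncnn2-c2cc(OC)c(OC)c(OC)c2)c1`: > 10000 nM
- compound 3 `COc1cc(-n2ncnc2-c2ccc(OC(F)(F)F)cc2)cc(OC)c1OC`: > 10000 nM

All three entries are limits, not numbers, so the series cannot be ranked: the limit of > 10000 nM in this assay, at which 3 of the 3 values shown sit. Compound 1 stands at its limit of > 10000 nM.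

Compound 4 `COc1cc(-c2ncnn2-c2ccccc2)cc(OC)c1OC` has hydrogen in place of fluoro on an aromatic carbon, meta to a large group, turning 3-fluorophenyl into phenyl: hydrogen in place of fluoro on an aromatic carbon. For the measured compounds named here, no measured pair shows the size of this change in this assay. No shift beyond the scatter is expected in either direction, and the estimated a number no higher from compound 1 to compound 4 (the limit leaves the size open) reflects this. For compound 4 the expected value is 10000 nM, with an estimated range of 3000 nM to 30000 nM.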

Compound 4, half-maximal inhibitory concentration: > 10000 nM
Compound 4: no number, only a limit (the forecaster's own chance of this, stated with the estimate: 80%); the middle value sits exactly at the limit.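

No new step can be read from compound 1 to compound 4, as both entries are limits rather than numbers: the limit of > 10000 nM in this assay, at which 4 of the 4 values shown sit.

The compounds shown leave open how far each lies beyond its limit and which structural change, if any, would give a measurable value.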